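This account rests on a few compounds, and the source may have more. Where it says the series, first, only, none or still open, it means among the compounds named here.

In a functional assay on MCF7 cells (Homo sapiens) for inhibition, read by MTT assay, with a stated time of 48 h (a higher number here means a weaker inhibitor, a lower number a stronger inhibitor), three compounds built on a shared core have been measured. Compound 1 `COc1ccc(CN(c2cc(OC)c(OC)c(OC)c2)S(=O)(=O)c2ccc(C(C)(C)C)cc2)cc1` gives 32700 nM. Compound 2 `COc1cc(N(Cc2cccc(C)c2)S(=O)(=O)c2ccc(C)cc2)cc(OC)c1OC` gives 14300 nM. Compound 3 `COc1cc(N(Cc2nc3ccccc3[nH]2)S(=O)(=O)c2ccc(F)cc2)cc(OC)c1OC` gives 9380 nM. Compound 3 holds the lowest number of the three, but the number of compound 2 sits within the scatter of it, so those two cannot be put in order; compound 1, by contrast, stands beyond the scatter above compound 3.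

Compound 4 `COc1cc(N(Cc2nc3ccccc3[nH]2)C(=O)c2cccc(Cl)c2)cc(OC)c1OC` has not yet been measured in this assay. It differs from compound 3 in a single place: (3-chlorophenyl)carbonyl in place of (4-fluorophenyl)sulfonyl on a nitrogen on an aromatic ring. Among the measured compounds shown here, no pair among the measured compounds differs in only one place, so the size of a step of this kind is not known from these data. What the three measured compounds do show is that, despite differing from one another in several places at once, their numbers in this assay lie close together. On that basis a step of little size, in no firm direction, is expected. Compound 4 is expected to give 9000 nM, with a range from 3000 nM to 30000 nM. The step that this estimate means, a 1.0-fold lower number from compound 3 to compound 4 (0.02 log units; within the scatter), is expected to stay within the scatter.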

Compound 4, half-maximal inhibitory concentration: 34900 nM
For compound 4 the middle estimate is 3.9-fold (0.59 log units) below the measured one; measured number above the stated range.
By their numbers in this assay, from the lowest: compounds 3 and 2 (each within the scatter of the next); then compounds 1 and 4 (each within the scatter of the next).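

In this assay, compound 3 and compound 4 form the only pair shown that differs in one place, and (3-chlorophenyl)carbonyl in place of (4-fluorophenyl)sulfonyl on the nitrogen on an aromatic ring gives a 3.7-fold higher number from compound 3 to compound 4 (0.57 log units; beyond the scatter). Among the compounds shown here, this modest step lies beyond the scatter and runs towards a weaker inhibitor, so the group on this nitrogen can move the number, something the earlier compounds, which all differ in several places at once, could not show. Nothing measured here accounts for the size or direction of this step.

The change replaces the sulfonyl with a carbonyl and also alters the halogen on the aromatic ring, so the compounds shown leave open which of these parts carries the step. Groups such as (4-fluorophenyl)carbonyl or (3-chlorophenyl)sulfonyl on the same nitrogen would separate the two parts, and it also remains open whether a simple methylsulfonyl or acetyl group there would give a number near that of compound 3 or that of compound 4.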